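Stereochemical inversion in a bicyclic enol acetate acetal series

A few compounds are considered here, and "the series" means these few. Any claim that something is new, unique, unknown or untested is made for them only; others in the source may bear on it.

Compound 1 `CC(=O)OC1OC=CC2C1CC[C@H]2O`: 16000 nM
Compound 2 `CC(=O)O[C@@H]1OC=C[C@@H]2[C@H]1[C@@H](C)C[C@H]2O[Si](c1ccccc1)(c1ccccc1)C(C)(C)C`: 1460 nM

Compound 2 gives the lowest number of the two measured in a functional assay on T47D cells (Homo sapiens) for antiproliferative activity, read by sulforhodamine B assay, with a stated time of 48 h; a lower number here means a stronger inhibitor of growth, a higher number a weaker inhibitor of growth; its nearest neighbour is compound 1, whose number is higher by a gap that lies beyond the scatter. Compound 3 `CC(=O)O[C@H]1OC=C[C@H]2[C@@H]1[C@H](C)C[C@H]2O[Si](c1ccccc1)(c1ccccc1)C(C)(C)C` is the compound still to be measured. It is related to compound 2 as follows: the two compounds have the same atoms and bonds and differ only in configuration as drawn: 4 of 5 stereo elements differ; a stereocentre at a saturated ring carbon is drawn S in compound 2 and R in compound 3; a stereocentre at a saturated ring carbon is drawn R in compound 2 and S in compound 3; a stereocentre at a saturated ring carbon is drawn R in compound 2 and S in compound 3; a stereocentre at a saturated ring carbon is drawn S in compound 2 and R in compound 3. Within the data shown here, no pair of measured compounds differs only in configuration, so the data give no guide to how large such a step tends to be, nor in which direction. Compound 3 is therefore expected near compound 2, with a wide range, at 2500 nM (from 600 nM to 12000 nM) in this assay. That estimate corresponds to a step of a 1.7-fold higher number from compound 2 to compound 3 (0.23 log units; within the scatter) expected to be small, with either direction possible.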

Compound 3, concentration for 50% growth inhibition: 1620 nM
Estimate against measurement, compound 3: 1.5-fold (0.19 log units) above; the measured number falls inside the stated range.
By their numbers in this assay, from the lowest: compounds 2 and 3 (each within the scatter of the next); then compound 1.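

In this assay, inverting four of the five stereo elements amounts to a 1.1-fold higher number from compound 2 to compound 3 (0.05 log units; within the scatter), so this read-out does not separate the two compounds. Among these compounds, earlier data offered no pair that isolated configuration, and this pair now shows that the four saturated ring carbons can all be drawn the opposite way with no difference in growth inhibition beyond the scatter. The finding rests on this one pair, and the comparison is clean on the following ground: the fact that compounds 2 and 3 differ only in the configuration as drawn

The compounds shown leave open what inverting any one of these stereocentres alone would do, or inverting the remaining fifth stereo element, as the four change together here. They also leave open whether a benzyl ether or an amine in place of the silyl ether would show the same indifference to configuration.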